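A few compounds are considered here, and "the series" means these few. Any claim that something is new, unique, unknown or untested is made for them only; others in the source may bear on it.

Of the compounds shown here, three sharing one core have so far been measured in a physicochemical assay for lipophilicity, at pH 7.4; on this read-out lower numbers stand for lower lipophilicity and higher numbers for higher lipophilicity. Compound 1 (`COc1cc2c(cc1OC)CN(c1ccc(C=O)cc1)CC2`) gives 3.7, and compound 2 (`COc1cc2c(cc1OC)CN(c1cccnc1)CC2`) gives 3.7. These two stand level, together the lowest of the three numbers. Compound 3 (`COc1cc2c(cc1OC)CN(c1cc(C(F)(F)F)cc(C(F)(F)F)c1)CC2`), which carries trifluoromethyl groups, gives 5.7, a gap to the other two that lies well beyond the ordinary scatter of repeated measurements.

The next compound to follow is compound 4 (`COc1cc2c(cc1OC)CN(c1ccccn1)CC2`), which departs from compound 2 in a single place. The change is this: pyridin-2-yl in place of pyridin-3-yl on an amine nitrogen in a ring. The two compounds have the same atoms, joined differently, so nothing is added or removed. Only the attachment changes, with pyridin-2-yl in place of pyridin-3-yl on an amine nitrogen in a ring.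

For the measured compounds named here, no two compounds measured so far differ in only one place, so the numbers offer no direct precedent for this swap. The natural starting point is therefore compound 2 itself, at 3.7. A small upward move is expected, a number 0.20 log units higher from compound 2 to compound 4 (within the scatter), a size that may not clear the scatter. In this assay the estimate for compound 4 is 3.9, with an expected range from 3.4 to 4.4.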

Compound 4, distribution coefficient: 3.7
For compound 4 the middle estimate is 0.20 log units above the measured one; measured number inside the range.
By their numbers in this assay, from the lowest: compounds 1, 2 and 4 (each within the scatter of the next); then compound 3.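

For the compounds shown here, this is the first step where only one place changes, so it gives a direct reading for this position. In this assay, pyridin-2-yl in place of pyridin-3-yl on an amine nitrogen in a ring gives no change at the digits printed from compound 2 to compound 4 (within the scatter), so for this pair, joining the same atoms differently leaves the read-out level. No measurement shown here speaks to why the two compounds stand level, and the result has to remain a plain observation.

The compounds shown leave open whether pyridin-4-yl, a plain phenyl or a pyrimidinyl group on the same nitrogen would also stay level with compound 2, and such steps would show how much the place of the ring nitrogen, or its presence at all, matters in this assay. As far as these compounds go, it is also open whether this result extends to other substituted rings at this position, such as one carrying an amine or a carboxylic acid, since a single pair cannot establish a pattern.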